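The source may hold more compounds than are shown below. What is called first, only, known or untested is meant among the compounds shown, and "the series" means these compounds.

Among the measured compounds shown here, compound 2, `Cc1cc(S(=O)(=O)/N=C(\N)n2nccc2-c2ccccc2)c(SCc2cccc3ccccc23)cc1Cl`, gives the lowest of the two numbers measured so far in a functional assay on HeLa cells (Homo sapiens) for cytotoxicity, read by MTT assay, with a stated time of 72 h; on this read-out lower numbers stand for stronger inhibition and higher numbers for weaker inhibition: compound 2 shows 3000 nM, while compound 1, `Cc1cc(S(=O)(=O)/N=C(\N)n2nccc2-c2ccccc2)c(SCc2ccccc2Cl)cc1Cl`, shows 19000 nM. For the measured compounds named here, the one step that connects them, a 6.3-fold lower number from compound 1 to compound 2 (0.80 log units; beyond the scatter), is the only guide available here. Compound 3, `Cc1cc(S(=O)(=O)/N=C(\N)n2nccc2-c2ccccc2)c(SCc2ccccc2)cc1Cl`, differs from compound 2 in a single place: phenyl in place of naphthalen-1-yl on a saturated chain carbon bound to a sulfur. The step from compound 1 to compound 2 bears on this change only indirectly, since it swapped a 2-chlorophenyl for the naphthalen-1-yl on the saturated chain carbon bound to a sulfur, and the number fell by a modest amount beyond the scatter. Compound 3 carries a phenyl, which shares one six-membered aromatic ring with the naphthalen-1-yl but lacks its second ring, and also lacks the chlorine of compound 1. Because compound 2 stands at 3000 nM and the naphthalen-1-yl gave the lower number, a higher number is expected for compound 3, with a 4.0-fold higher number from compound 2 to compound 3 (0.60 log units; beyond the scatter) as the estimated size of the step. Compound 3 is accordingly estimated at 12000 nM in this assay, with a likely range from 4000 nM to 40000 nM.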

Compound 3, half-maximal inhibitory concentration: 5000 nM
For compound 3 the middle estimate is 2.4-fold (0.38 log units) above the measured one; the range from low to high includes it.
By their numbers in this assay, from the lowest: compounds 2 and 3 (each within the scatter of the next); then compound 1.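

In this assay, the change from naphthalen-1-yl to phenyl on the saturated chain carbon bound to a sulfur gives a 1.7-fold higher number from compound 2 to compound 3 (0.22 log units; within the scatter), so the second aromatic ring of the naphthalen-1-yl makes no difference that this read-out can resolve, and the earlier step from the 2-chlorophenyl to the naphthalen-1-yl cannot be read as a gain that depends on that second ring. The new comparison with compound 1 isolates a different change, hydrogen in place of chloro on an aromatic carbon, and gives a 3.8-fold lower number from compound 1 to compound 3 (0.58 log units; beyond the scatter), which lies beyond the scatter; among the three compounds, the chloro-bearing compound 1 therefore stands apart, while the unsubstituted phenyl and the naphthalen-1-yl stay together. Nothing given here accounts for either result, and the numbers alone offer no explanation for them.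

The compounds shown leave open whether the higher number of compound 1 is specific to chloro at that ring carbon, or would also appear with a fluoro, a methoxy or a carboxylic acid on the phenyl. They also leave open how a longer chain, such as 2-phenylethyl in place of the benzyl, would read in this assay.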